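Benzyl amide variations on the dihydroxy acid series

A few compounds are considered here, and "the series" means these few. Any claim that something is new, unique, unknown or untested is made for them only; others in the source may bear on it.

Compound 1 `CC(C)c1c(C(=O)NCc2ccccc2)nn(-c2ccc(F)cc2)c1OC[C@@H](O)C[C@@H](O)CC(=O)O` gives 880 nM in a functional assay on L6 cells (Rattus norvegicus) for inhibition; a lower number here means a stronger inhibitor, a higher number a weaker inhibitor. Compound 2 `CC(C)c1c(C(=O)NCC2CCCCC2)nn(-c2ccc(F)cc2)c1OC[C@@H](O)C[C@@H](O)CC(=O)O` carries a cyclohexylmethyl amide in place of the benzyl amide, but in this assay compound 2 gives "not determined" (no result reported), so it stands nowhere on the measured scale. Compound 3 `COCc1cccc(CNC(=O)c2nn(-c3ccc(F)cc3)c(OC[C@@H](O)C[C@@H](O)CC(=O)O)c2C(C)C)c1` differs from compound 2 by 3-(methoxymethyl)phenyl in place of cyclohexyl on a saturated chain carbon bound to an amide-type nitrogen. Compound 3 thus returns to a benzyl-type amide as in compound 1, and the step from compound 2 to compound 3 in this assay is expected to stay near the result of compound 1, with no direction beyond the scatter claimed. Compound 3 is estimated at 700 nM, in the range 200 nM to 2500 nM.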

Compound 3, half-maximal inhibitory concentration: 3600 nM
Beside the measured number, compound 3's estimate is 5.1-fold (0.71 log units) below it, and the stated range ends below it.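

In this assay the benzyl amide does not carry the added group without a loss: methoxymethyl in place of hydrogen on an aromatic carbon gives a 4.1-fold higher number from compound 1 to compound 3 (0.61 log units; beyond the scatter). The step from cyclohexyl to 3-(methoxymethyl)phenyl cannot be read, as compound 2 has no result. Nothing at hand explains the higher number for compound 3.

Open, from the compounds shown here alone, is whether this step belongs to methoxymethyl itself or to any group at that aromatic carbon. A methoxy group, a fluorine or an amine there would separate the two.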